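The source may report more compounds than this note shows. Statements on the series, on what has been measured and on what is new or still open speak of the compounds shown alone.

Measured so far in a functional assay on the whole organism (strain Wistar) for inhibition, with Rattus norvegicus as the target, read by paw edema, with stated times of 60 min and 4 h, at a dose of 100 mg/kg by the oral route; on this read-out lower numbers stand for less inhibition and higher numbers for more inhibition at the one dose given (going by the name of the read-out):

Compound 1 `CNC(=O)CC1CCc2cc(OC)c(OC)cc21` gives 29.7%.
Compound 2 `COc1cc2c(cc1OC)C(CC(=O)N1CCCCC1)CC2` gives 32%.

Within the data shown here, only two compounds have been measured, and their numbers sit close together. Among the measured compounds shown here, the one step between them, a number 2.3 percentage points higher from compound 1 to compound 2 (within the scatter), swaps one amine group on the carbonyl carbon for another and leaves the read-out essentially where it was. Compound 2 is therefore not separated from compound 1 by anything that counts.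

Compound 3 `COc1cc2c(cc1OC)C(CC(=O)NCCO)CC2` is the next compound in line. It differs from compound 2 at the same carbonyl carbon: (2-hydroxyethyl)amino in place of piperidin-1-yl on a carbonyl carbon. For the measured compounds named here, the one step that bears on this kind of change is a number 2.3 percentage points higher from compound 1 to compound 2 (within the scatter), which was small. Changing the amine on that carbonyl carbon once more is thus expected to give no step beyond the scatter, so the estimated step is a number 2 percentage points lower from compound 2 to compound 3 (within the scatter). For compound 3 the expected value in this assay is 30%, with a range from 15% to 45%.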

Compound 3, a percentage reported as inhibition, in the whole organism at one dose (the size of the read-out at that dose, not a potency): 9.37%
For compound 3 the middle estimate is 20.6 percentage points above the measured one; measured number below the stated range.
By their numbers in this assay, from the lowest: compound 3; then compounds 1 and 2 (each within the scatter of the next).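

In this assay, the amine on this carbonyl carbon turns out to matter: (2-hydroxyethyl)amino in place of piperidin-1-yl gives a number 22.6 percentage points lower from compound 2 to compound 3 (beyond the scatter) and so moves the read-out beyond the scatter, which the earlier swap of amines did not do. A smaller change has a similar effect, since hydroxymethyl in place of hydrogen on a saturated chain carbon bound to an amide-type nitrogen gives a number 20.3 percentage points lower from compound 1 to compound 3 (beyond the scatter) and shows that the amide need not lose its ring to fall this far. Nothing measured here explains the fall.

On these data alone, it remains open whether the hydroxyl itself matters or the chain that carries it. A 2-methoxyethylamino or ethylamino group on the same carbonyl carbon would bear on this, as would a longer chain such as 3-hydroxypropylamino.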